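From Phenyl to 3-Bromophenyl in a Cytotoxic Pair

The compounds below may be only part of what the source reports. "The series", "measured", "known", "first", "only" and "open" are said of these compounds alone.

Of the compounds shown here, two have so far been measured in a functional assay on HeLa cells (Homo sapiens) for cytotoxicity, read by MTT assay, with a stated time of 48 h; a lower number here means a stronger inhibitor, a higher number a weaker inhibitor. Compound 1 (`CC(C)=CCC/C(C)=C/CC/C(C)=C/CC[C@@H]1[C@@]2(C)CC/C(=N\OCc3cn(-c4ccccc4)nn3)C(C)(C)[C@@H]2CC[C@@]1(C)O`) gives 7760 nM. Compound 2 (`CC(C)=CCC/C(C)=C/CC/C(C)=C/CC[C@@H]1[C@@]2(C)C/C(=C\c3ccc(OCc4cn(-c5ccccc5)nn4)cc3)C(=O)C(C)(C)[C@@H]2CC[C@@]1(C)O`) gives 36300 nM, the higher of the two numbers, and its gap to compound 1 lies beyond the scatter. These two compounds differ in more than one place, so the gap cannot be assigned to any single group.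

Compound 3 (`CC(C)=CCC/C(C)=C/CC/C(C)=C/CC[C@@H]1[C@@]2(C)C/C(=C\c3ccc(OCc4cn(-c5cccc(Br)c5)nn4)cc3)C(=O)C(C)(C)[C@@H]2CC[C@@]1(C)O`) departs from compound 2 at one site: bromo in place of hydrogen on an aromatic carbon. This change turns phenyl into 3-bromophenyl. For the measured compounds named here, no measured pair in this set shows what such a replacement does, so the expectation starts from compound 2 at 36300 nM and assumes little movement. No step beyond the scatter is expected in this assay, with at most a slight lean towards a lower number. The estimated step of a 1.2-fold lower number from compound 2 to compound 3 (0.08 log units; within the scatter) therefore stays small. For compound 3 the expected value is 30000 nM, with an estimated range from 14000 nM to 65000 nM.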

Compound 3, half-maximal inhibitory concentration: 37200 nM
Estimate against measurement, compound 3: 1.2-fold (0.09 log units) below; low and high end bracket the measured number.
By their numbers in this assay, from the lowest: compound 1; then compounds 2 and 3 (each within the scatter of the next).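

In this assay, the set now holds its first pair that differs in one place only, and it reads a 1.0-fold higher number from compound 2 to compound 3 (0.01 log units; within the scatter). Bromo in place of hydrogen on this aromatic carbon, which turns the phenyl of the 1-phenyl-1H-1,2,3-triazol-4-yl group into 3-bromophenyl, therefore gives two compounds that this assay cannot tell apart, so this position takes a bromine atom without a step beyond the scatter. Nothing measured here bears on why the two compounds read alike.

This single step does not show whether the same would hold for bromo elsewhere on the phenyl, or for another group at this place, such as methoxy, an amine or a carboxylic acid. Nor do the compounds shown tell whether 3-bromophenyl would read the same on the core of compound 1, which carries the same 1-phenyl-1H-1,2,3-triazol-4-yl group on a different linkage.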